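A few compounds are considered here, and "the series" means these few. Any claim that something is new, unique, unknown or untested is made for them only; others in the source may bear on it.

Measured compounds:
compound 1, `Cc1cc(-c2ccc(C#N)cc2)cc(C)c1Oc1cc(N)nc(Nc2ccc(C#N)cc2)n1`: 18100 nM
compound 2, `Cc1cc(-c2ccc(C#N)c(F)c2)cc(C)c1Oc1cc(N)nc(Nc2ccc(C#N)cc2)n1`: 5000 nM
compound 3, `Cc1cc(-c2ccccc2)ccc1Oc1cc(N)nc(Nc2ccc(C#N)cc2)n1`: 20000 nM

All three were tested in a toxicity assay on MT4 cells (Homo sapiens) for cytotoxicity, read by MTT assay; a higher number here means that more compound is tolerated, a lower number that less compound is tolerated. Compound 1 and compound 2 share one core, while compound 3 is built on another; the difference between the two cores is not broken down here. In this assay compound 1 gives 18100 nM and compound 3 gives 20000 nM, and these two values lie within the scatter of each other. Compound 2 carries fluoro in place of hydrogen on an aromatic carbon, and that change produced a 3.6-fold lower number from compound 1 to compound 2 (0.56 log units; beyond the scatter). In this assay compound 2 gives 5000 nM.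

Compound 4, `Cc1cc(-c2ccccc2F)ccc1Oc1cc(N)nc(Nc2ccc(C#N)cc2)n1`, has not yet been measured. It differs from compound 3 by fluoro in place of hydrogen on an aromatic carbon. Among the measured compounds shown here, this is the same kind of change as the one from compound 1 to compound 2, but not the same: there the fluoro entered ortho to a cyano group and meta to a large group, here it enters ortho to a large group. For the measured compounds named here, only one earlier example of this kind of change exists, and it sits in a different surrounding, so it is a weak guide. Going by the values given here, a step of a 1.7-fold lower number from compound 3 to compound 4 (0.22 log units; within the scatter) is expected, smaller than the earlier one, because the only comparable step is a 3.6-fold lower number from compound 1 to compound 2 (0.56 log units; beyond the scatter) and its setting differs. For compound 4 the expected value in this assay is 12000 nM. The value of compound 4 is estimated to fall between 5000 nM and 28000 nM.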

Compound 4, half-maximal cytotoxic concentration: 29500 nM
The estimate for compound 4 lay 2.5-fold (0.39 log units) below the measured number; the measured number lies above the stated range.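

In this assay, replacing a hydrogen on an aromatic carbon with fluoro, here turning phenyl into 2-fluorophenyl with the fluoro ortho to a large group, gives a 1.5-fold higher number from compound 3 to compound 4 (0.17 log units; within the scatter), so on this core the change leaves no readable effect on how much compound the cells tolerate. Set beside the earlier example, the same kind of change does not carry over from one core to the other with the same size: the same change on two cores in this assay, a 3.6-fold lower number (0.56 log units; beyond the scatter) from compound 1 to compound 2 and a 1.5-fold higher number (0.17 log units; within the scatter) from compound 3 to compound 4, 5.3-fold (0.73 log units) apart, beyond the scatter of two such steps What this does not show is whether the core alone sets that gap, as the two pairs also differ in the surroundings of the fluoro, and two pairs cannot give a rule for the whole series.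

The compounds shown leave open whether fluoro would give the same result when placed elsewhere on the phenyl group of compound 3, and whether the same placement on both cores would bring the two steps together. They also leave open whether a chloro, methyl or methoxy group in place of the fluoro of compound 4 would give a step that can be told from the scatter.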